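The source may hold more compounds than are shown below. What is called first, only, known or untested is meant among the compounds shown, and "the series" means these compounds.

Measured in a functional assay on IMR-32 cells (Homo sapiens) for inhibition, with a stated time of 48 h, tested at 50 uM; on this read-out lower numbers stand for less inhibition of growth and higher numbers for more inhibition of growth at the one concentration tested:
compound 1 `C=C[C@@](C)(/C=C/c1ccc(OC(C)=O)cc1)CCC=C(C)C`: 71%
compound 2 `C=C[C@@](C)(/C=C/c1ccc(OC(=O)CC)cc1)CCC=C(C)C`: 63%
compound 3 `C=C[C@@](C)(/C=C/c1ccc(OC(=O)CCCC)cc1)CCC=C(C)C`: 21%

Among these three, compound 3 has the lowest value, 21%, and it sits beyond the scatter from both others. Compound 4 `C=C[C@@](C)(/C=C/c1ccc(OC(=O)CCCCCCC)cc1)CCC=C(C)C` has not yet been measured. It differs from compound 3 by propyl in place of hydrogen on a saturated chain carbon, four bonds along the chain from a carbonyl carbon, so the chain on the carbonyl carbon grows further, with propyl in place of hydrogen four bonds along the chain from that carbon.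

Three measured steps extend the same chain. The shortest extension gave a number 8 percentage points lower from compound 1 to compound 2 (within the scatter), which is no clear change. The two longer extensions gave a number 50 percentage points lower from compound 1 to compound 3 (beyond the scatter) and a number 42 percentage points lower from compound 2 to compound 3 (beyond the scatter), both large. Over these three compounds a longer chain therefore goes with a lower number, although the first step does not show this beyond the scatter. A second fall on the scale of a number 42 percentage points lower from compound 2 to compound 3 (beyond the scatter) would carry the number past zero, so the data leave room for only a smaller drop. The expected change is a modest fall, probably not clearly beyond the scatter, and it is estimated as a number 9 percentage points lower from compound 3 to compound 4 (within the scatter). For compound 4 the estimated value is 12%, with an expected range from 0% to 30%.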

Compound 4, percent growth inhibition at one concentration: 51%
Estimate against measurement, compound 4: 39 percentage points below, outside the stated range (above it).
By their numbers in this assay, from the lowest: compound 3; then compound 4; then compounds 2 and 1 (each within the scatter of the next).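

In this assay, lengthening the chain on the carbonyl carbon does not keep lowering the number: propyl in place of hydrogen on a saturated chain carbon, four bonds along the chain from a carbonyl carbon, gave a number 30 percentage points higher from compound 3 to compound 4 (beyond the scatter). Compound 4 therefore goes against the fall seen among the three shorter chains, yet the rise does not fully restore the earlier level, as shown by a number 12 percentage points lower from compound 2 to compound 4 (beyond the scatter) and by a number 20 percentage points lower from compound 1 to compound 4 (beyond the scatter). Among the four compounds, growth inhibition thus follows no single direction with chain length at this position, compound 3 marks the lowest number, and nothing at hand gives a reason for this turn.

Going by these compounds, it remains open how the number behaves for chains of intermediate length between those of compound 3 and compound 4, and whether a longer chain would extend the rise or reverse it. It is also open whether a branched chain, or an amine or a carboxylic acid at the end of the chain, would follow the same course, and whether the order of these compounds would hold at other concentrations.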